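Methyl on the shared core: the pyrrolidine thiosemicarbazone

The compounds below may be only part of what the source reports. "The series", "measured", "known", "first", "only" and "open" are said of these compounds alone.

Measured compounds in a functional assay on A-431 cells (Homo sapiens) for cytotoxicity, read by MTT assay, with a stated time of 72 h, tested at 10 uM; a higher number here means more inhibition of growth at the concentration tested, a lower number less inhibition of growth:
compound 1, `Cc1ccnc(/C(N)=N/NC(=S)N2CCSCC2)c1`: 60%
compound 2, `N/C(=N\NC(=S)N1CCSCC1)c1ccccn1`: 61.4%
compound 3, `N/C(=N\NC(=S)N1CCCC1)c1ccccn1`: 77.2%

Compound 3 stands highest of the three numbers in this assay. Its nearest neighbour is compound 2, and the step of a number 15.8 percentage points higher from compound 2 to compound 3 (beyond the scatter) comes with pyrrolidin-1-yl in place of thiomorpholin-4-yl on a thiocarbonyl carbon. Compound 1 lies furthest away.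

Compound 4, `Cc1ccnc(/C(N)=N/NC(=S)N2CCCC2)c1`, is not yet measured. It differs from compound 3 by methyl in place of hydrogen on an aromatic carbon. Among the measured compounds shown here, one measured step bears on this change, in the reverse direction: a number 1.4 percentage points higher from compound 1 to compound 2 (within the scatter), where hydrogen replaced methyl on the same aromatic carbon with the thiomorpholine-bearing thiocarbonyl. That step stayed within the scatter, so the methyl group, on the evidence of compounds 1 and 2, is not expected to move the number beyond the scatter in either direction.

Compound 4 is therefore expected to give 76% in this assay, between 62% and 88%, a step of a number 1.2 percentage points lower from compound 3 to compound 4 (within the scatter) that is expected to stay within the scatter.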

Compound 4, percent growth inhibition at one concentration: 71.2%
Estimate against measurement, compound 4: 4.8 percentage points above, and the stated range covers the measured number.
By their numbers in this assay, from the lowest: compounds 1, 2, 4 and 3 (each within the scatter of the next, the first and the last beyond it).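

On the core of compound 3, methyl on this aromatic carbon, opposite the ring nitrogen, gives in this assay a number 6 percentage points lower from compound 3 to compound 4 (within the scatter) and so leaves the read-out within the scatter here as well. With both the thiomorpholin-4-yl and the pyrrolidin-1-yl group on the thiocarbonyl carbon, the change from methyl to hydrogen now reads the same: the same change on two cores in this assay, a number 1.4 percentage points higher (within the scatter) from compound 1 to compound 2 and a number 6 percentage points higher (within the scatter) from compound 4 to compound 3, 4.6 percentage points apart, within the scatter of two such steps. The exchange of thiomorpholin-4-yl for pyrrolidin-1-yl also carries over to the methyl-bearing core, with a number 11.2 percentage points higher from compound 1 to compound 4 (beyond the scatter) and agreement with the step on the core without methyl: the same change on two cores in this assay, a number 15.8 percentage points higher (beyond the scatter) from compound 2 to compound 3 and a number 11.2 percentage points higher (beyond the scatter) from compound 1 to compound 4, 4.6 percentage points apart, within the scatter of two such steps.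

Only hydrogen and methyl are shown on this carbon, so it remains open whether ethyl, methoxy or an amine there would also stay within the scatter. On these data alone, how a piperidine or a morpholine on the thiocarbonyl carbon would compare also remains open.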